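The source may hold more compounds than are shown below. What is called first, only, known or untested is meant among the compounds shown, and "the series" means these compounds.

Measured compounds in an assay on COS-7 cells for inhibition of patatin-like phospholipase domain-containing protein 2 (Mus musculus); a higher number here means a weaker inhibitor, a lower number a stronger inhibitor:
compound 1 `CCOc1ccc(-c2cccc(S(=O)(=O)N(C)C)c2)cc1`: 110000 nM
compound 2 `CCOc1ccc(-c2cccc(S(=O)(=O)NC)c2)cc1`: 200000 nM
compound 3 `CCOc1ccc(-c2cccc(C(=O)O)c2)cc1`: > 200000 nM

Compound 3 is reported only as a limit of this assay, > 200000 nM, so its place is known only as the weakest end of what the three values show, and the line the limit of > 200000 nM in this assay, at which 1 of the 3 values shown sits, is the one at which it sits. The step of an at least 1.8-fold higher number from compound 1 to compound 3 (0.25 log units; that floor lies within the scatter) and the step of a number no lower from compound 2 to compound 3 (the limit leaves the size open) are the two measured steps that bear on the carboxy group; the first is a floor within the scatter, the second is open in size. Compound 4 `CCOc1ccc(-c2cccc(C(=O)OCC(F)(F)F)c2)cc1` differs from compound 3 by 2,2,2-trifluoroethyl in place of hydrogen on an oxygen next to a carbonyl group, in words: 2,2,2-trifluoroethyl in place of hydrogen on an oxygen next to a carbonyl group. Among the measured compounds shown here, no measured step covers this change directly; the neutral compounds 1 and 2 give numbers, the acid compound 3 gives only a limit, so a number around theirs is the nearest guide. For compound 4 the step of an at least 1.3-fold lower number from compound 3 to compound 4 (0.12 log units; that floor lies within the scatter) is therefore expected to be small and unreadable in direction. Compound 4 is estimated at 150000 nM, between 50000 nM and 400000 nM, with a fair chance of another limit.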

Compound 4, half-maximal inhibitory concentration: 120000 nM
Estimate against measurement, compound 4: 1.3-fold (0.10 log units) above; low and high end bracket the measured number.
By their numbers in this assay, from the lowest: compounds 1, 4 and 2 (each within the scatter of the next).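

In this assay, 2,2,2-trifluoroethyl in place of hydrogen on the oxygen next to the carbonyl group gives a readable number at this position, where the free carboxy group gave none: compound 4 gives 120000 nM. The change reads as an at least 1.6-fold lower number from compound 3 to compound 4 (0.22 log units; that floor lies within the scatter), so the data give only a floor and no firm gain, because the starting value is a limit: the limit of > 200000 nM in this assay, at which 1 of the 4 values shown sits. Compounds 1, 4 and 2 each lie within the scatter of the next, so the ester falls in the same band as the two sulfonamides, with no order among the three.

On these data alone, how far the carboxy compound really stands from this band stays open. Also open, as far as these compounds go, is whether an amide, an amine or a longer chain on that oxygen would move the number beyond the scatter.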